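The source may hold more compounds than are shown below. What is called first, only, known or untested is meant among the compounds shown, and "the series" means these compounds.

Compound 1 `C=CCOc1ccc(C(=O)/C=C/c2cc(OC)cc(OC)c2)cc1` gives 25000 nM in a functional assay (Homo sapiens) for inhibition; a lower number here means a stronger inhibitor, a higher number a weaker inhibitor. Compound 2 `C=CCOc1ccc(C(=O)/C=C/c2cc(OC)c(OC)c(OC)c2)cc1` carries the change methoxy in place of hydrogen on an aromatic carbon and in this assay compound 2 gives 30000 nM, so the step of a 1.2-fold higher number from compound 1 to compound 2 (0.08 log units; within the scatter) is slight. Compound 3 `COc1cccc(OC)c1/C=C/C(=O)c1ccc(O)cc1` rests on another core; the difference between the two cores is not broken down here. In this assay compound 3 gives 60000 nM. Compound 4 `COc1cc(OC)c(/C=C/C(=O)c2ccc(O)cc2)c(OC)c1` follows from compound 3 by methoxy in place of hydrogen on an aromatic carbon. This is the same kind of change as from compound 1 to compound 2, though the surroundings differ: there the entering methoxy is ortho to two methoxy groups, here it is meta to two methoxy groups, para to a large group in both. For compound 4 a step of about a 1.2-fold higher number from compound 3 to compound 4 (0.07 log units; within the scatter) is expected, because the earlier step of a 1.2-fold higher number from compound 1 to compound 2 (0.08 log units; within the scatter) stayed within the scatter. Compound 4 is estimated at 70000 nM, between 30000 nM and 160000 nM.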

Compound 4, half-maximal inhibitory concentration: 44000 nM
Beside the measured number, compound 4's estimate is 1.6-fold (0.20 log units) above it, within the range that was stated.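

In this assay the new step is a 1.4-fold lower number from compound 3 to compound 4 (0.13 log units; within the scatter), so methoxy in place of hydrogen on an aromatic carbon stays within the scatter on both cores, and the two steps do not differ: the same change on two cores in this assay, a 1.2-fold higher number (0.08 log units; within the scatter) from compound 1 to compound 2 and a 1.4-fold lower number (0.13 log units; within the scatter) from compound 3 to compound 4, 1.6-fold (0.21 log units) apart, within the scatter of two such steps. This supports only a limited reading: in these two pairs, with the entering methoxy in different surroundings, the change leaves the number within the scatter on each core. It does not show that the same would hold on any other core, and steps this small give no measure of how well a larger effect would carry over.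

Still open, going by these compounds, is whether an amine or a carboxylic acid in place of that hydrogen would give a step beyond the scatter on either core. The difference between the two cores also stays open, as no pair shown differs in the core alone.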